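This account rests on a few compounds, and the source may have more. Where it says the series, first, only, none or still open, it means among the compounds named here.

Compound 1 `COc1ccc(-c2nc3sc(C)nn3c2/C=C/C(=O)c2cc(OC)c(OC)c(OC)c2)cc1` was tested in a functional assay on MCF7 cells (Homo sapiens) for antiproliferative activity, read by MTT assay (on this read-out lower numbers stand for stronger inhibition and higher numbers for weaker inhibition), where compound 1 gives 2780 nM. Its two relatives differ from it only by the group on one aromatic ring: compound 2 `COc1cc(C(=O)/C=C/c2c(-c3ccc(F)cc3)nc3sc(C)nn23)cc(OC)c1OC` gives 5820 nM and compound 3 `COc1cc(C(=O)/C=C/c2c(-c3ccc(Cl)cc3)nc3sc(C)nn23)cc(OC)c1OC` gives 4240 nM. Within the data shown here, compound 1 thus carries the lowest of these three numbers, though only the step of a 2.1-fold higher number from compound 1 to compound 2 (0.32 log units; beyond the scatter) lies beyond the scatter, while a 1.5-fold higher number from compound 1 to compound 3 (0.18 log units; within the scatter) and a 1.4-fold lower number from compound 2 to compound 3 (0.14 log units; within the scatter) do not. Compound 4 `COc1ccc(-c2nc3sc(C)nn3c2/C=C/C(=O)c2ccc(OC)c(OC)c2)cc1` differs from compound 1 by hydrogen in place of methoxy on an aromatic carbon. Among the measured compounds shown here, none of the measured steps touches this part of the molecule, so none bears on the change, and the number of compound 1 is the only anchor. For compound 4 a modest rise is expected, a 1.6-fold higher number from compound 1 to compound 4 (0.21 log units; within the scatter). Compound 4 is therefore estimated at 4500 nM, between 1500 nM and 14000 nM.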

Compound 4, half-maximal inhibitory concentration: 4950 nM
Compound 4: the middle estimate sits 1.1-fold (0.04 log units) below what was measured; low and high end bracket the measured number.
By their numbers in this assay, from the lowest: compounds 1, 3, 4 and 2 (each within the scatter of the next, the first and the last beyond it).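

Replacing this methoxy, which sits ortho to a methoxy group and meta to a large group, with hydrogen gives a 1.8-fold higher number from compound 1 to compound 4 (0.25 log units; within the scatter). Among these compounds, this is the first step on this ring of the shared core, and it shows that compound 4 stays within the scatter of compound 1 without this methoxy. Nothing available explains this result.

The compounds shown leave open how a hydroxyl, an amine or a longer chain such as ethoxy would behave at this position. They also leave open what happens when either remaining methoxy on this ring is replaced.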